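The compounds below may be only part of what the source reports. "The series", "measured", "known", "first", "only" and "open" are said of these compounds alone.

Within the data shown here, in an ADME assay on HEK293 cells (Homo sapiens) for cytotoxicity, read by MTT assay, with a stated time of 72 h (on this read-out lower numbers stand for stronger inhibition and higher numbers for weaker inhibition), two compounds have numbers so far: compound 1 `Cc1ccc(C(=O)N2CCN(CC(=O)N3CCN(CCCc4c[nH]c5ccc(F)cc45)CC3)CC2)cc1` gives 141000 nM and compound 2 `O=C(CN1CCN(C(=O)c2ccc(F)cc2)CC1)N1CCN(CCCc2c[nH]c3ccc(F)cc23)CC1` gives 102000 nM. These two values lie within the usual scatter of each other, so compound 2 cannot be told apart from compound 1 on this read-out. Compound 3 `O=C(CN1CCN(C(=O)c2cccc(Br)c2)CC1)N1CCN(CCCc2c[nH]c3ccc(F)cc23)CC1` differs from compound 2 in one place: 3-bromophenyl in place of 4-fluorophenyl on a carbonyl carbon. Put simply, 3-bromophenyl stands in place of 4-fluorophenyl on a carbonyl carbon. Among the measured compounds shown here, only one measured step bears on this change: a 1.4-fold lower number from compound 1 to compound 2 (0.14 log units; within the scatter), with fluoro in place of methyl on an aromatic carbon. For the measured compounds named here, no measured compound carries 3-bromophenyl, so this is thin evidence, and no step beyond the scatter is expected in this assay. The expected change is a 1.0-fold lower number from compound 2 to compound 3 (0.01 log units; within the scatter). For compound 3 the estimated value is 100000 nM, within a range of 50000 nM to 200000 nM.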

Compound 3, half-maximal inhibitory concentration: 40600 nM
Compound 3: middle estimate off by 2.5-fold (0.39 log units), on the high side, outside the stated range (below it).
By their numbers in this assay, from the lowest: compound 3; then compounds 2 and 1 (each within the scatter of the next).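

In this assay, the group on this carbonyl carbon can shift the number beyond the scatter, which the earlier pair of compounds did not show. Putting 3-bromophenyl in place of 4-fluorophenyl gives a 2.5-fold lower number from compound 2 to compound 3 (0.40 log units; beyond the scatter), and putting it in place of 4-methylphenyl gives a 3.5-fold lower number from compound 1 to compound 3 (0.54 log units; beyond the scatter), so compound 3 stands apart from both earlier compounds, which could not be told apart from each other. Nothing available explains why this change lowers the number.

Both the halogen and its place on the ring differ between compound 2 and compound 3, so the compounds shown cannot separate these two changes. On these data alone, how a phenyl ring carrying chlorine, a methoxy group or an amine would behave on this carbonyl carbon also remains open.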